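A few compounds are considered here, and "the series" means these few. Any claim that something is new, unique, unknown or untested is made for them only; others in the source may bear on it.

Compound 1 `CC(=O)Oc1cccc(N2C(=O)/C(=C/N3N=C(c4ccccc4)CC3c3ccccc3O)SC2=S)c1`: > 10000 nM
Compound 2 `CC(=O)Oc1ccc(N2C(=O)/C(=C/N3N=C(c4ccccc4)CC3c3ccccc3O)SC2=S)cc1`: 244 nM

Among the compounds with values here, compound 2 holds the only number given in a functional assay on SK-OV-3 cells (Homo sapiens) for antiproliferative activity, read by MTT assay, with a stated time of 72 h; a higher number here means a weaker inhibitor, a lower number a stronger inhibitor. Compound 1 sits at a limit of this assay, (the limit of > 10000 nM in this assay, at which 1 of the 2 values shown sits). Within the data shown here, the single measured step, an at least 40-fold lower number from compound 1 to compound 2 (1.61 log units; beyond the scatter), shows how much the group on the ring nitrogen can matter. Compound 3 `CN1C(=O)/C(=C/N2N=C(c3ccccc3)CC2c2ccccc2O)SC1=S` differs from compound 2 in that (methyl in place of 4-acetoxyphenyl on an amide-type nitrogen in a ring). Among the measured compounds shown here, no measured step removes the aryl group altogether, so the expectation leans on that one step. Given the size of an at least 40-fold lower number from compound 1 to compound 2 (1.61 log units; beyond the scatter), compound 3 is expected to be weaker, at an estimated 2000 nM (range 300 nM to 12000 nM). The expected step is an 8.2-fold higher number from compound 2 to compound 3 (0.91 log units; beyond the scatter).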

Compound 3, half-maximal inhibitory concentration: 341 nM
Beside the measured number, compound 3's estimate is 5.9-fold (0.77 log units) above it; the range from low to high includes it.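

With a 1.4-fold higher number from compound 2 to compound 3 (0.15 log units; within the scatter), the 4-acetoxyphenyl group and a methyl on the ring nitrogen cannot be told apart in this assay, so an aryl group at this place is not needed for activity. With an at least 29-fold lower number from compound 1 to compound 3 (1.46 log units; beyond the scatter), the weak result goes with the 3-acetoxyphenyl group alone among the three groups shown. The value of compound 1 is a limit: the limit of > 10000 nM in this assay, at which 1 of the 3 values shown sits. From the compounds shown here alone, whether a longer chain, a carboxylic acid or an amine on this nitrogen would keep the activity stays open, as does where an unsubstituted phenyl would fall.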